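Indole for pyrrole on the benzyl-type arm

This account rests on a few compounds, and the source may have more. Where it says the series, first, only, none or still open, it means among the compounds named here.

Compound 2 `COc1ccc2[nH]c(C(=O)N3CC(=O)N(Cc4ccc[nH]4)[C@@H](Cc4ccccc4)C3)cc2c1` carries a (1H-pyrrol-2-yl)methyl group on the ring amide nitrogen of the shared core. Among the compounds with values here, in a physicochemical assay for solubility, read by spectrophotometry, in phosphate buffer, with a stated time of 2 h, at pH 7.4 (a higher number here means a more soluble compound, a lower number a less soluble compound), compound 2 gives 38400 nM, the only plain number in this set. Compound 1 `COc1ccc2[nH]c(C(=O)N3CC(=O)N(Cc4ccccc4)[C@@H](CN4CCCCC4)C3)cc2c1` is reported in this assay only as a limit, > 25000 nM (the limit of > 25000 nM in this assay, at which 1 of the 2 values shown sits). Compound 3 `COc1ccc2[nH]c(C(=O)N3CC(=O)N(Cc4c[nH]c5ccccc45)[C@@H](Cc4ccccc4)C3)cc2c1` is the untested partner of compound 2: its structural change is 1H-indol-3-yl in place of 1H-pyrrol-2-yl on a saturated chain carbon bound to an amide-type nitrogen in a ring, which read one bond further out is (1H-pyrrol-2-yl)methyl to (1H-indol-3-yl)methyl. No measured step in this assay links any two of these compounds, so the expected size rests on the change alone. The expectation is a step downward in this assay, from compound 2 to compound 3 of about a 2.7-fold lower number from compound 2 to compound 3 (0.44 log units; beyond the scatter), beyond the usual scatter. Compound 3 is estimated at 14000 nM, with a range from 4500 nM to 40000 nM.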

Compound 3, solubility: 10300 nM
Beside the measured number, compound 3's estimate is 1.4-fold (0.13 log units) above it; low and high end bracket the measured number.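

In this assay, the place on a saturated chain carbon bound to an amide-type nitrogen in a ring now has its first readable step, a 3.7-fold lower number from compound 2 to compound 3 (0.57 log units; beyond the scatter), for 1H-indol-3-yl in place of 1H-pyrrol-2-yl. Within the data shown here, the earlier compounds offered no such pair, so this is the first sign that the group at this place can shift the read-out beyond the scatter, here with a six-membered aromatic ring of carbon only added to the arm. Nothing shown here gives a cause for this step.

On these data alone, whether an amine or a carboxylic acid at the same place would raise or lower the number remains open. Compound 1 stands only as a limit, > 25000 nM, and differs from compound 2 in more than one place, so its step cannot be read.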